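A few compounds are considered here, and "the series" means these few. Any claim that something is new, unique, unknown or untested is made for them only; others in the source may bear on it.

Measured so far in a physicochemical assay for lipophilicity, read by HPLC, measured as octanol-water partition, at pH 7.4; on this read-out higher numbers stand for higher lipophilicity and lower numbers for lower lipophilicity:
- compound 1 `NC(=O)[C@@H](CCC(F)(F)F)N(CC1COC1)S(=O)(=O)c1ccc(Cl)cc1` — 2.5
- compound 2 `NC(=O)[C@@H](CCC(F)(F)F)N(C[C@H]1COCCO1)S(=O)(=O)c1ccc(Cl)cc1` — 2.75

On these two numbers compound 1 stands lowest in this assay with 2.5; its nearest neighbour is compound 2, and the step of a number 0.25 log units higher from compound 1 to compound 2 (within the scatter) is within the scatter, so the two are not separated by this assay.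

Compound 3 `NC(=O)[C@@H](CCC(F)(F)F)N(C[C@@H]1CCCO1)S(=O)(=O)c1ccc(Cl)cc1` is the next member to be measured. Relative to compound 1 the change is oxolan-2-yl in place of oxetan-3-yl on a saturated chain carbon bound to a sulfonamide nitrogen

Among the compounds with values here, only one measured step bears on this change: the replacement of the same oxetan-3-yl by 1,4-dioxan-2-yl at the same place, which gave a number 0.25 log units higher from compound 1 to compound 2 (within the scatter). That step exchanged a four-membered ring with one hetero atom for a six-membered ring with two hetero atoms. Here a five-membered ring with one hetero atom enters instead, so the step is expected to be in the same direction but somewhat larger, and a number 0.60 log units higher from compound 1 to compound 3 (beyond the scatter) is the estimated move from compound 1, probably just beyond the scatter. The expected value for compound 3 in this assay is 3.1, with a range from 2.7 to 3.5.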

Compound 3, distribution coefficient: 3.5
Compound 3: middle estimate off by 0.40 log units, on the low side; low and high end bracket the measured number.
By their numbers in this assay, from the lowest: compounds 1 and 2 (each within the scatter of the next); then compound 3.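

Oxolan-2-yl in place of oxetan-3-yl on a saturated chain carbon bound to a sulfonamide nitrogen gives a number 1.00 log units higher from compound 1 to compound 3 (beyond the scatter) in this assay and, in place of 1,4-dioxan-2-yl at the same place, a number 0.75 log units higher from compound 2 to compound 3 (beyond the scatter) as well, so this position now separates ring groups, which the first pair did not show. The order does not follow ring size: the five-membered ring of compound 3 stands above both the four-membered ring of compound 1 and the six-membered ring of compound 2, and those two are not separated from each other; nor does the hetero atom count settle it, since compound 1 and compound 3 each carry one hetero atom in the ring. Nothing at hand accounts for the size of these steps.

From the compounds shown here alone, whether the ring oxygen matters here stays open, and a cyclopentyl group or an open-chain 2-methoxyethyl group at this place would speak to that. Also open, going by these compounds, are the opposite stereoisomer of the oxolan-2-yl group of compound 3 and the reading for a ring amine such as pyrrolidin-2-yl.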